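Changing the Group on the Carbonyl Carbon

The source may report more compounds than this note shows. Statements on the series, on what has been measured and on what is new or still open speak of the compounds shown alone.

Compound 1 `CC(=O)Oc1ccccc1C(=O)NCC[Se]C#N`: 5500 nM
Compound 2 `CC(=O)Oc1ccccc1C(=O)OCC[Se]C#N`: 23800 nM
Compound 3 `CC(=O)Oc1ccccc1C(=O)[Se]CC[Se]C(=O)c1ccccc1OC(C)=O`: 11000 nM

In a functional assay on MDA-MB-231 cells (Homo sapiens) for antiproliferative activity, read by MTT assay, with a stated time of 48 h (on this read-out higher numbers stand for weaker inhibition and lower numbers for stronger inhibition), compound 2 gives the highest of the three numbers, its nearest neighbour being compound 3 and its furthest compound 1. Compound 4 `CC(=O)Oc1ccccc1C(=O)[Se]CC[Se]C#N` differs from compound 2 by a group of 6 heavy atoms (3 carbon, 1 nitrogen, 2 selenium; no ring) in place of a group of 6 heavy atoms (3 carbon, 1 nitrogen, 1 oxygen, 1 selenium; no ring), on a carbonyl carbon. For the measured compounds named here, only one measured step touches the same carbonyl carbon: a 4.3-fold higher number from compound 1 to compound 2 (0.64 log units; beyond the scatter), so a swap there has moved the number beyond the scatter once. Compound 3, which carries the entering kind of group twice, gives 11000 nM, a lower number than compound 2. The expected step is therefore a 2.4-fold lower number from compound 2 to compound 4 (0.38 log units; beyond the scatter), toward a lower number. Compound 4 is estimated at 10000 nM, within 3500 nM to 28000 nM.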

Compound 4, half-maximal inhibitory concentration: 34200 nM
The estimate for compound 4 lay 3.4-fold (0.53 log units) below the measured number, outside the stated range (above it).
By their numbers in this assay, from the lowest: compounds 1 and 3 (each within the scatter of the next); then compounds 2 and 4 (each within the scatter of the next).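

In this assay, the group with a second selenium and the group with oxygen on the carbonyl carbon cannot be told apart, with a 1.4-fold higher number from compound 2 to compound 4 (0.16 log units; within the scatter) for this swap. The group with nitrogen now stands apart from both, as a 6.2-fold higher number from compound 1 to compound 4 (0.79 log units; beyond the scatter) joins the earlier 4.3-fold higher number from compound 1 to compound 2 (0.64 log units; beyond the scatter) on the same carbon. Nothing measured here explains why the group with nitrogen stands apart.

Open, on these data alone, is whether a group with sulfur on this carbonyl carbon would fall with the nitrogen group or with the other two. Also open, as far as these compounds go, is whether a longer chain would keep this separation.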